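This account rests on a few compounds, and the source may have more. Where it says the series, first, only, none or still open, it means among the compounds named here.

Series notes on an ADME assay on cells (Homo sapiens) for cytotoxicity, read by polymerase chain reaction, with a stated time of 3 days; on this read-out lower numbers stand for higher toxicity in this test and higher numbers for lower toxicity in this test. Compound 1 `COCCNc1nc(C)c(-c2nc3ccccc3s2)c(N[C@@H]2C[C@H](CO)[C@@H](O)[C@H]2O)n1` gives 21000 nM in this assay. Compound 2 `Cc1nc(NCCNS(C)(=O)=O)nc(N[C@@H]2C[C@H](CO)[C@@H](O)[C@H]2O)c1-c1nc2ccccc2s1` reaches only a limit in this assay, > 25000 nM, which is the limit of > 25000 nM in this assay, at which 1 of the 3 values shown sits. Compound 3 `Cc1nc(NCCCC(F)(F)F)nc(N[C@@H]2C[C@H](CO)[C@@H](O)[C@H]2O)c1-c1nc2ccccc2s1` gives 3000 nM in this assay and so holds the lowest of the two numbers shown, with compound 1 the nearest at a higher number. The step of a 7.0-fold lower number from compound 1 to compound 3 (0.85 log units; beyond the scatter) and the step of an at least 8.3-fold lower number from compound 2 to compound 3 (0.92 log units; beyond the scatter) run the same way: trifluoroethyl in place of methoxy or of methanesulfonamido on the same chain carbon lowers the number beyond the scatter.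

Compound 4 `Cc1nc(NCc2cccnc2)nc(N[C@@H]2C[C@H](CO)[C@@H](O)[C@H]2O)c1-c1nc2ccccc2s1` is not yet measured; it differs from compound 3 by pyridin-3-yl in place of 3,3,3-trifluoropropyl on a saturated chain carbon bound to a nitrogen on an aromatic ring. Among the measured compounds shown here, the steps that bear on this change are those reaching compound 3 from compounds 1 and 2, each modest in size, each leading from a methoxy or methanesulfonamido chain to a fluorinated one. For the measured compounds named here, compound 4 turns this around in kind, a pyridin-3-yl ring carrying a hydrogen-bond acceptor entering where the 3,3,3-trifluoropropyl leaves, although the ring itself has no counterpart among the measured compounds. A higher number than compound 3 is therefore expected, back toward the region of compound 1. Compound 4 is estimated at 12000 nM in this assay, in the range 4000 nM to 30000 nM. The expected step is a 4.0-fold higher number from compound 3 to compound 4 (0.60 log units; beyond the scatter).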

Compound 4, half-maximal cytotoxic concentration: 5000 nM
Compound 4: middle estimate off by 2.4-fold (0.38 log units), on the high side, and the stated range covers the measured number.
By their numbers in this assay, from the lowest: compounds 3 and 4 (each within the scatter of the next); then compound 1. At a limit, above all of these: compound 2.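

Working notes on this assay: the low number at this position does not depend on the fluorinated chain, as a 1.7-fold higher number from compound 3 to compound 4 (0.22 log units; within the scatter) shows, with pyridin-3-yl taking the place of 3,3,3-trifluoropropyl on the same saturated chain carbon. Until now, only the fluorinated chain had given a number beyond the scatter of the others, whereas a chain ending in a ring now moves the same way, with a 4.2-fold lower number from compound 1 to compound 4 (0.62 log units; beyond the scatter) and an at least 5.0-fold lower number from compound 2 to compound 4 (0.69 log units; beyond the scatter). Compound 2 stands at a limit, so its step gives only a floor: the limit of > 25000 nM in this assay, at which 1 of the 4 values shown sits.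

The compounds shown leave open whether the low numbers of compound 3 and compound 4 extend to other chain ends, such as a phenyl ring, a longer alkyl chain, an amine or a carboxylic acid, or whether the methoxy and methanesulfonamido chains of compound 1 and compound 2 are the exceptions. With a single ring example, they also leave open whether the ring nitrogen of pyridin-3-yl matters at all, a question that the phenyl analogue would address directly.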